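Swapping the amine substituent in a gut-hormone receptor agonist series

The compounds below may be only part of what the source reports. "The series", "measured", "known", "first", "only" and "open" are said of these compounds alone.

Measured so far:
Compound 1 `CC1(OC(=O)N2CCC(O[C@H]3CC[C@H](Oc4cnc(S(C)(=O)=O)cn4)CC3)CC2)CC1`: 123%
Compound 2 `CS(=O)(=O)c1cnc(O[C@H]2CC[C@H](OC3CCN(CC4(C(F)(F)F)CCCC4)CC3)CC2)cn1`: 88%

Both compounds were tested in a functional assay on isolated protein for agonist activity at Glucose-dependent insulinotropic receptor (Rattus norvegicus), read by HTRF and cAMP accumulation; on this read-out higher numbers stand for larger maximal responses and lower numbers for smaller maximal responses. Compound 2 stands lowest of the two numbers, and its nearest neighbour is compound 1, which lies higher by a step described as beyond the scatter.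

Compound 3 `CC(C)c1noc(CN2CCC(O[C@H]3CC[C@H](Oc4cnc(S(C)(=O)=O)cn4)CC3)CC2)n1` has not been measured. It differs from compound 2 in one place: a group of 8 heavy atoms (5 carbon, 2 nitrogen, 1 oxygen; one five-membered aromatic ring with 3 hetero atoms) in place of a group of 9 heavy atoms (6 carbon, 3 fluorine; one five-membered non-aromatic ring of carbon only), on a saturated chain carbon bound to an amine nitrogen in a ring.

For the measured compounds named here, only one measured step can inform this change, a number 35 percentage points lower from compound 1 to compound 2 (beyond the scatter), and it concerns a different exchange at the ring amine, so it is a loose guide at best. It shows that altering the group on that nitrogen can move the maximal response by a large amount in either direction. Without a closer precedent, the expected step of a number 12 percentage points higher from compound 2 to compound 3 (beyond the scatter) is uncertain, and compound 3 is estimated at 100%, within a range of 75% to 125%.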

Compound 3, largest response reached (Emax), in percent of the reference or control that the assay uses: 115%
For compound 3 the middle estimate is 15 percentage points below the measured one, and the stated range covers the measured number.
By their numbers in this assay, from the lowest: compound 2; then compounds 3 and 1 (each within the scatter of the next).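

In this assay, the step of a number 27 percentage points higher from compound 2 to compound 3 (beyond the scatter) shows that a large maximal response is possible with a saturated chain carbon bound to the ring amine nitrogen, once the fluorine-bearing group with the five-membered carbon ring gives way to 3-isopropyl-1,2,4-oxadiazol-5-yl. The step of a number 8 percentage points lower from compound 1 to compound 3 (within the scatter) adds that (3-isopropyl-1,2,4-oxadiazol-5-yl)methyl and ((1-methylcyclopropyl)oxy)carbonyl cannot be told apart on this read-out, although they are different groups on that nitrogen. Nothing available here explains why the response follows these exchanges.

The compounds shown leave open how much of the response belongs to the aromatic ring and how much to its isopropyl group. A plain methyl or a tert-butyl group in place of that isopropyl would begin to separate the two.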